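This account rests on a few compounds, and the source may have more. Where it says the series, first, only, none or still open, it means among the compounds named here.

Compound 3 `CNc1nc(=O)ccn1[C@@H]1O[C@H](COP(=O)(O)O)[C@@H](O)[C@H]1O` gives in an in vitro functional assay on 1321-N1 cells for agonist activity at P2Y purinoceptor 4 (Homo sapiens), read by scintillation proximity assay and inositol phosphate accumulation (on this read-out lower numbers stand for an effect already at smaller amounts and higher numbers for an effect only at larger amounts of compound), a reading that is a limit of the assay, not a number: > 100000 nM (the limit of > 100000 nM in this assay, at which 1 of the 3 values shown sits). Compound 1 `CCSc1nc(=O)ccn1[C@@H]1O[C@H](COP(=O)(O)O)[C@@H](O)[C@H]1O` gives in this assay a measured value of 4330 nM. Compound 2 `O=c1ccn([C@@H]2O[C@H](COP(=O)(O)OP(=O)(O)O)[C@@H](O)[C@H]2O)c(SCCc2ccccc2)n1` gives in this assay a limit as well, >= 100000 nM (the limit of >= 100000 nM in this assay, at which 1 of the 3 values shown sits). The change from compound 3 to compound 4 `O=c1ccn([C@@H]2O[C@H](COP(=O)(O)O)[C@@H](O)[C@H]2O)c(SCCc2ccccc2)n1` is phenethylsulfanyl in place of methylamino on an aromatic carbon. Among the compounds with values here, one measured step bears on it, running the opposite way: an at least 23-fold higher number from compound 1 to compound 3 (1.36 log units; beyond the scatter). Compound 2 also carries phenethylsulfanyl and stands at a limit, which tempers the expectation. Compound 4 is therefore expected to leave the limit and reach a lower number, as a step of an at least 5.0-fold lower number from compound 3 to compound 4 (0.69 log units; beyond the scatter). The estimate for compound 4 is 20000 nM, expected between 3000 nM and 150000 nM.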

Compound 4, half-maximal effective concentration: > 100000 nM
Compound 4 gave a limit, no number; the forecaster's own chance of this, stated with the estimate: 30%; middle value at least 5.0-fold (0.69 log units) away from the limit.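

Compound 4 stays at a limit of this assay, not a number: the limit of > 100000 nM in this assay, at which 2 of the 4 values shown sit.

On the aromatic carbon between two ring nitrogen atoms, a sulfur-linked chain therefore does not by itself give a measured value, since adding phenyl to the ethylsulfanyl chain produces an at least 23-fold higher number from compound 1 to compound 4 (1.36 log units; beyond the scatter). The steps to compound 4 from compound 2 and from compound 3 cannot be read, as both ends of each are limits.

The compounds shown leave open whether methylsulfanyl or propylsulfanyl at this position would give a measured value. They also leave open how much chain length the position tolerates short of phenethylsulfanyl.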